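This account rests on a few compounds, and the source may have more. Where it says the series, first, only, none or still open, it means among the compounds named here.

Three compounds have been run through an ADME assay (liver) for metabolic stability, with Liver microsome (Rattus norvegicus) as the target, read by LC-MS, using microsomes and NADPH, with stated times of 5 min and 60 min, tested at 4 uM (on this read-out higher numbers stand for a more stable compound and lower numbers for a less stable compound), so far. Compound 1, with the structure `COc1cc(C(=O)O)ccc1OCCCCOc1ccc(C(=O)CC(C)(C)C)c(O)c1C`, gives 49% in this assay. Compound 2, with the structure `Cc1c(OCCCCOc2cccc(C(=O)O)c2)ccc(C(=O)CC(C)C)c1C`, gives 29%, and compound 3, with the structure `CCCC(=O)c1ccc(OCCCCOc2cc(C(=O)O)ccc2OC)c(C)c1O`, gives 1%. Among these three results compound 2 stands second highest: compound 1 sits a good deal higher, and compound 3 a good deal lower, both gaps wider than the usual scatter of this assay.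

The next compound, compound 4 with the structure `Cc1c(OCCCCOc2cccc(C(=O)O)c2)ccc(C(=O)CC(C)C)c1O`, differs from compound 2 in a single place: hydroxy in place of methyl on an aromatic carbon. For the measured compounds named here, no two of the measured compounds differ from each other in just one place, so no single step has been recorded that could show what this kind of exchange does on its own. Both compound 1 and compound 3 carry a hydroxy group, yet their results lie at opposite ends of the range, which leaves the direction open. For the step from compound 2 to compound 4 in this assay a change of a number 4 percentage points lower from compound 2 to compound 4 (within the scatter) is expected, which is not beyond the scatter. For compound 4 the estimated value is 25%, with a range from 8% to 45%.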

Compound 4, percent of the compound remaining: 51%
The estimate for compound 4 lay 26 percentage points below the measured number, and the stated range ends below it.
By their numbers in this assay, from the lowest: compound 3; then compound 2; then compounds 1 and 4 (each within the scatter of the next).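

In this assay, putting hydroxy in place of methyl on this aromatic carbon, ortho to a methyl group and ortho to an isobutylcarbonyl group, comes with a number 22 percentage points higher from compound 2 to compound 4 (beyond the scatter) as the change. For the compounds shown here, this is the first comparison in the set where only one place differs, so the effect of this exchange can now be read directly, and in this pair the compound carrying hydroxy is the more stable one. The data shown include no measurement that accounts for this rise, so its cause remains unknown.

One pair cannot show whether the gain is specific to hydroxy or whether another group on the same carbon, such as an amine or a fluorine atom, would give a similar result. It also leaves open whether the same exchange would move the number in the same direction and by a similar amount if the isobutylcarbonyl group were replaced by another group, such as an amide.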